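This account rests on a few compounds, and the source may have more. Where it says the series, first, only, none or still open, it means among the compounds named here.

Measured so far:
Compound 1 `O=C(/C=C/c1coc2cc(O)ccc2c1=O)NCc1ccc(F)cc1` — 357000 nM
Compound 2 `COc1ccc2c(=O)c(/C=C/C(=O)Nc3cccc(Cl)c3)coc2c1` — 1100000 nM
Compound 3 `COc1ccc2c(=O)c(/C=C/C(=O)Nc3ccc(C)cc3)coc2c1` — 979000 nM

All three numbers come from an ADME assay on HepG2 2.2.15 cells (Homo sapiens) for cytotoxicity, read by MTT assay, with stated times of 48 h and 9 days; a lower number here means that less compound is tolerated, a higher number that more compound is tolerated. Compound 3 holds the second highest of the three; compound 2 lies within the scatter of it, so the two cannot be told apart, while compound 1 sits beyond the scatter on the lower side. Compound 4 `COc1ccc2c(=O)c(/C=C/C(=O)NCc3cccc(F)c3)coc2c1` has not been measured yet. It differs from compound 3 in one place: 3-fluorobenzyl in place of 4-methylphenyl on an amide-type nitrogen. Among the measured compounds shown here, the only measured step touching this nitrogen is a 1.1-fold lower number from compound 2 to compound 3 (0.05 log units; within the scatter), which stayed within the scatter. Compound 1, whose structure differs from compound 3 in more than one place, gives a lower number, so a modest fall seems plausible but is uncertain. Compound 4 is estimated at 700000 nM, with a range from 300000 nM to 1500000 nM. That estimate corresponds to an expected step of a 1.4-fold lower number from compound 3 to compound 4 (0.15 log units; within the scatter).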

Compound 4, half-maximal cytotoxic concentration: 475000 nM
The estimate for compound 4 lay 1.5-fold (0.17 log units) above the measured number; low and high end bracket the measured number.
By their numbers in this assay, from the lowest: compounds 1 and 4 (each within the scatter of the next); then compounds 3 and 2 (each within the scatter of the next).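

In this assay, this amide nitrogen now proves sensitive to what it carries: 3-fluorobenzyl in place of 4-methylphenyl gives a 2.1-fold lower number from compound 3 to compound 4 (0.31 log units; beyond the scatter) and 3-fluorobenzyl in place of 3-chlorophenyl gives a 2.3-fold lower number from compound 2 to compound 4 (0.36 log units; beyond the scatter). Both steps are modest but beyond the scatter, unlike the exchange between the two phenyl groups. No supporting data explain the fall. Still open, on these data alone, is whether the benzyl link or the fluorine carries the change. A plain benzyl group or a longer chain ending in an amine on this nitrogen would extend the comparison.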